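The source may report more compounds than this note shows. Statements on the series, on what has been measured and on what is new or still open speak of the compounds shown alone.

Compound 1 `CC(=O)n1cc(/C=C(/C(=O)O)c2ccccc2)c2cc(OCc3ccccc3)ccc21` already carries an acetyl on the aromatic nitrogen of the shared core. In a functional assay on LNCaP cells (Homo sapiens) for cytotoxicity, read by MTT assay, with a stated time of 72 h (on this read-out lower numbers stand for stronger inhibition and higher numbers for weaker inhibition), compound 1 returns only a limit, > 100000 nM, and not a number. Compound 2 `COc1ccc(/C(=C\c2c[nH]c3ccc(OCc4ccccc4)cc23)C(=O)O)cc1` has a hydrogen on that nitrogen instead; for compound 2 no result was reported in this assay, "not determined" (no result reported), so compound 2 stands nowhere on the numbers shown. Going by the values given here, the only other reading in this assay is the one for compound 1, and that one is not a number. Compound 3 `COc1ccc(/C(=C\c2cn(C(C)=O)c3ccc(OCc4ccccc4)cc23)C(=O)O)cc1` differs from compound 2 in one place: acetyl in place of hydrogen on an aromatic nitrogen. Among the compounds with values here, no measured pair separates the free nitrogen from the acetylated one, so the step from compound 2 to compound 3 in this assay cannot be sized from the data; the author expects no shift that could be told apart from the limit, since compound 3 shares the acetyl with compound 1 and that compound sits at the limit of > 100000 nM in this assay, at which 1 of the 2 values shown sits. Compound 3 is therefore expected to give about 100000 nM in this assay, within 30000 nM to 300000 nM, and most likely to be reported again as a limit.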

Compound 3, half-maximal inhibitory concentration: 85000 nM
For compound 3 the middle estimate is 1.2-fold (0.07 log units) above the measured one; the measured number falls inside the stated range.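

Going by these compounds alone, compound 3 gives the first reading in this assay that is a number and not a limit, 85000 nM, and it does so with the acetyl on the aromatic nitrogen kept in place. Methoxy in place of hydrogen on an aromatic carbon accounts for the one readable step, an at least 1.1-fold lower number from compound 1 to compound 3 (0.07 log units; that floor lies within the scatter), so this change is shown only as a floor, and that floor gives no evidence of a real gain. The number for compound 3 therefore sits close to the limit, which remains among the readings: the limit of > 100000 nM in this assay, at which 1 of the 3 values shown sits.

On these data alone, with no result for compound 2, the step from hydrogen to acetyl on the aromatic nitrogen cannot be read, and the part that this acetyl plays in the weak readings stays unknown. Also open, as far as these compounds go, is how a longer acyl chain or an amine on that nitrogen, or a hydroxyl in place of the methoxy, would read in this assay.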